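A few compounds are considered here, and "the series" means these few. Any claim that something is new, unique, unknown or untested is made for them only; others in the source may bear on it.

Measured compounds:
compound 1 `COC(=O)N[C@H](C(=O)N1CCC[C@H]1C(=O)Nc1ccc([C@@H]2CC[C@@H](c3ccc(NC(=O)[C@@H]4CCCN4C(=O)[C@@H](NC(=O)OC)C(C)C)cc3)N2c2ccc([Si](C)(C)C)cc2)cc1)C(C)C` — 101%
compound 2 `CC[Si](CC)(CC)c1ccc(N2[C@H](c3ccc(NC(=O)[C@@H]4CCCN4C(=O)[C@@H](NC(=O)OC)C(C)C)cc3)CC[C@H]2c2ccc(NC(=O)[C@@H]3CCCN3C(=O)[C@@H](NC(=O)OC)C(C)C)cc2)cc1` — 98%

Compound 1 `COC(=O)N[C@H](C(=O)N1CCC[C@H]1C(=O)Nc1ccc([C@@H]2CC[C@@H](c3ccc(NC(=O)[C@@H]4CCCN4C(=O)[C@@H](NC(=O)OC)C(C)C)cc3)N2c2ccc([Si](C)(C)C)cc2)cc1)C(C)C` was run in an ADME assay on microsomes from liver (Rattus norvegicus) for metabolic stability, read by HPLC, using NADPH, with stated times of 5 min and 60 min, tested at 0.2 uM (a higher number here means that more of the compound is left, a lower number that less of the compound is left), where compound 1 gives 101%. Compound 2 `CC[Si](CC)(CC)c1ccc(N2[C@H](c3ccc(NC(=O)[C@@H]4CCCN4C(=O)[C@@H](NC(=O)OC)C(C)C)cc3)CC[C@H]2c2ccc(NC(=O)[C@@H]3CCCN3C(=O)[C@@H](NC(=O)OC)C(C)C)cc2)cc1` gives 98% in this assay. On the numbers shown compound 1 sits at the top, yet the step of a number 3 percentage points lower from compound 1 to compound 2 (within the scatter) lies within the scatter, so the two compounds cannot be told apart.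

Compound 3 `COC(=O)N[C@H](C(=O)N1CCC[C@H]1C(=O)Nc1ccc([C@@H]2CC[C@@H](c3ccc(NC(=O)[C@@H]4CCCN4C(=O)[C@@H](NC(=O)OC)C(C)C)cc3)N2c2ccc([Si](C)(C)C(C)(C)C)cc2)cc1)C(C)C` has not been measured. It differs from compound 1 by tert-butyl in place of methyl on a silicon. Among the compounds with values here, the one measured step bears on it only loosely, as it also enlarged the groups carried by that silicon, and it changed the read-out very little. Compound 3 is therefore expected to stay near the top, with an expected step of a number 6 percentage points lower from compound 1 to compound 3 (within the scatter) not beyond the scatter. The estimate for compound 3 is 95%, expected to fall between 80% and 105%.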

Compound 3, percent of the compound remaining: 87%
For compound 3 the middle estimate is 8 percentage points above the measured one; low and high end bracket the measured number.
By their numbers in this assay, from the lowest: compound 3; then compounds 2 and 1 (each within the scatter of the next).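

In this assay, tert-butyl in place of methyl on a silicon gives a number 14 percentage points lower from compound 1 to compound 3 (beyond the scatter) and so shows that this position does respond to a change in the groups on the silicon. The comparison with compound 2 gives a number 11 percentage points lower from compound 2 to compound 3 (beyond the scatter) even though the group on the aromatic carbon has the same count of heavy atoms in both compounds, so among these compounds that count alone does not set the read-out. The data shown give no measured reason for this drop.

Going by these compounds, it remains open how isopropyl or phenyl on the silicon would compare with methyl and tert-butyl. On these data alone, it is also open whether a carbon in place of the silicon would give a different read-out.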